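Replacing Bromo with 2-Hydroxyphenyl: An Expected Outcome

The source may report more compounds than this note shows. Statements on the series, on what has been measured and on what is new or still open speak of the compounds shown alone.

Measured in a functional assay on K562 cells (Homo sapiens) for inhibition, with a stated time of 72 h; a higher number here means a weaker inhibitor, a lower number a stronger inhibitor:
- compound 1 `NC1CCC(Nc2nc(NCc3ccc(Br)cc3)c3ncn(C4CCCC4)c3n2)CC1`: 1170 nM
- compound 2 `CC(C)(O)CNc1nc(NCc2ccc(-c3ccco3)cc2)c2ncn(C3CCCC3)c2n1`: 16800 nM
- compound 3 `CC(C)(O)CNc1nc(NCc2ccc(-c3ccco3)nc2)c2ncn(C3CCCC3)c2n1`: 1430 nM

Compound 1 lies within the scatter of compound 3, and the values of both are well under that of compound 2. Compound 4 `NC1CCC(Nc2nc(NCc3ccc(-c4ccccc4O)cc3)c3ncn(C4CCCC4)c3n2)CC1` has not yet been measured. It differs from compound 1 in one place, with 2-hydroxyphenyl in place of bromo on an aromatic carbon, para to a large group (2-hydroxyphenyl in place of bromo on an aromatic carbon).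

Among the measured compounds shown here, no measured pair makes this exchange. The nearest evidence is a 12-fold lower number from compound 2 to compound 3 (1.07 log units; beyond the scatter), a large step that came with 6-(furan-2-yl)pyridin-3-yl in place of 4-(furan-2-yl)phenyl. It shows that a change in an aromatic group can move the number a long way, but it is a different change, made on a different side chain. It also gives no direction for compound 4, since compound 2, at 16800 nM, and compound 3, at 1430 nM, both carry a second ring yet end far apart. No step beyond the scatter is therefore expected in this assay, only an estimated 1.7-fold lower number from compound 1 to compound 4 (0.22 log units; within the scatter), with real uncertainty either way. For compound 4 the estimated value is 700 nM, with an expected range from 120 nM to 4000 nM.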

Compound 4, half-maximal inhibitory concentration: 2610 nM
Estimate against measurement, compound 4: 3.7-fold (0.57 log units) below; the range from low to high includes it.
By their numbers in this assay, from the lowest: compounds 1, 3 and 4 (each within the scatter of the next, the first and the last beyond it); then compound 2.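

In this assay, the exchange of bromo for 2-hydroxyphenyl on an aromatic carbon, para to a large group, brought a 2.2-fold higher number from compound 1 to compound 4 (0.35 log units; beyond the scatter) and so moved the number only modestly, though beyond the scatter. Among the compounds shown here, this is the first direct reading at this place on the side chain of compound 1: the only earlier step changed a different aromatic group in a different setting, whereas here a whole aromatic ring with a hydrogen-bond donor enters where a single bromine stood, and compound 4 still gives 2610 nM as a measurable number in the same range. What lies behind this shift cannot be said, as nothing at hand bears on it.

An unsubstituted phenyl or a 2-methoxyphenyl on this carbon would help separate the part played by the added ring from that of its hydroxyl, and a 3-hydroxyphenyl or 4-hydroxyphenyl would test where the hydroxyl sits. Also open, on these data alone, is whether a furan-2-yl group or the pyridine exchange behind a 12-fold lower number from compound 2 to compound 3 (1.07 log units; beyond the scatter) would carry over to the side chain of compound 1 or compound 4.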